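A Swapped Group on an Amine Nitrogen

A few compounds are considered here, and "the series" means these few. Any claim that something is new, unique, unknown or untested is made for them only; others in the source may bear on it.

- Compound 1 `O=[N+]([O-])c1ccc(NC(=S)NCCNS(=O)(=O)c2ccc(-c3ccccc3OCc3cccc(O)c3)s2)cc1`: 10100 nM
- Compound 2 `O=C(NCCNS(=O)(=O)c1ccc(-c2ccccc2O[C@H]2CC[C@H](O)CC2)s1)Nc1cc(Cl)cc(Cl)c1`: 14100 nM

In a functional assay on RS4-11 cells (Homo sapiens) for inhibition, read by CCK-8 assay, with a stated time of 48 h (a lower number here means a stronger inhibitor, a higher number a weaker inhibitor), compound 2 gives 14100 nM, the higher of the two numbers but within the scatter of compound 1 at 10100 nM. Compound 3 `O=[N+]([O-])c1ccc(NC(=S)NCCNS(=O)(=O)c2ccc(-c3ccccc3O[C@H]3CC[C@H](O)CC3)s2)cc1` departs from compound 2 on an amine nitrogen: a group of 12 heavy atoms (7 carbon, 2 nitrogen, 2 oxygen, 1 sulfur; one six-membered aromatic ring of carbon only) in place of a group of 11 heavy atoms (7 carbon, 1 nitrogen, 1 oxygen, 2 chlorine; one six-membered aromatic ring of carbon only), on an amine nitrogen. Among the measured compounds shown here, no measured step shows what this change does, and both values so far lie close together. The expected change is a 1.3-fold lower number from compound 2 to compound 3 (0.11 log units; within the scatter), which is none beyond the scatter. For compound 3 the estimated value is 11000 nM, with an expected range of 4000 nM to 30000 nM.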

Compound 3, half-maximal inhibitory concentration: 1500 nM
Beside the measured number, compound 3's estimate is 7.3-fold (0.87 log units) above it; the whole stated range lies above it.
By their numbers in this assay, from the lowest: compound 3; then compounds 1 and 2 (each within the scatter of the next).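

In this assay, the group on the amine nitrogen clearly counts: replacing (3,5-dichlorophenyl)carbamoyl gives a 9.4-fold lower number from compound 2 to compound 3 (0.97 log units; beyond the scatter). The group on the oxygen on an aromatic ring counts as well, with 4-hydroxycyclohexyl in place of 3-hydroxybenzyl giving a 6.7-fold lower number from compound 1 to compound 3 (0.83 log units; beyond the scatter), so the closeness of compound 1 and compound 2 concealed two separate steps. Nothing available here explains either step. The compounds shown leave open whether an acetyl group on the amine nitrogen would keep this level, and whether an amine could stand in for the hydroxyl of 4-hydroxycyclohexyl.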